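This account rests on a few compounds, and the source may have more. Where it says the series, first, only, none or still open, it means among the compounds named here.

Measured so far:

Compound 1, `CCOC(=O)c1sc2nc(C3CC3)cc(C(F)(F)F)c2c1N` — in an ADME assay on Huh-7 cells (Homo sapiens) for cytotoxicity, read by MTT assay, with a stated time of 72 h (a lower number here means that less compound is tolerated, a higher number that more compound is tolerated), compound 1 gives > 20000 nM, which is a limit of the assay and not a number.

Compound 2, `CCOC(=O)c1sc2nc(-c3ccco3)cc(C(F)(F)F)c2c1N` — in this assay compound 2 gives > 20000 nM, again a limit rather than a number.

Among the compounds with values here, compound 1 therefore stands only at a limit, and the one other value shown is a limit as well; both sit at the limit of > 20000 nM in this assay, at which 2 of the 2 values shown sit. Within the data shown here, the single measured step, a step that the two limits leave unreadable from compound 1 to compound 2, cannot be read, since two limits give no size.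

The unmeasured compound 3, `NC(=O)c1sc2nc(C3CC3)cc(C(F)(F)F)c2c1N`, differs from compound 1 by amino in place of ethoxy on a carbonyl carbon. No measured step bears directly on this change; the only step shown, from compound 1 to compound 2, is at a different place and is unreadable. With both known values at the limit, the expectation is that compound 3 will also be tolerated up to the limit, with no step beyond the scatter; the estimated step from compound 1 to compound 3 is a step that the limit leaves unreadable from compound 1 to compound 3. Compound 3 is therefore estimated at 25000 nM, within a range of 10000 nM to 60000 nM, most likely again reported only as a limit.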

Compound 3, half-maximal cytotoxic concentration: > 20000 nM
Compound 3 was reported as a limit; the forecaster's own chance of this, stated with the estimate: 80%; the middle value is on the limit's open side.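

Compound 1 and compound 3 each give only a limit in this assay, and no size can be read for the change from ethoxy to amino on the carbonyl carbon. The compounds shown leave open at what concentration any of them becomes toxic to the cells, and whether either change shifts that concentration at all.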